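Notes on the shared core: chain replacement at the amine

The source may hold more compounds than are shown below. What is called first, only, known or untested is meant among the compounds shown, and "the series" means these compounds.

Measured so far:
Compound 1, `CSc1nc(NCCCc2ccccc2)c2ccccc2n1`, in a functional assay on HTB-54 cells (Homo sapiens) for cytotoxicity, read by MTT assay, with a stated time of 72 h (a lower number here means a stronger inhibitor of growth, a higher number a weaker inhibitor of growth), gives > 100000 nM, which is a limit of the assay, not a number.
Compound 2, `CSc1nc(NCc2ccccc2)c2ccccc2n1`, in this assay gives 82300 nM.

Within the data shown here, compound 2 holds the only number; the other result, that of compound 1, sits at a limit, as noted in the limit of > 100000 nM in this assay, at which 1 of the 2 values shown sits. Both results mark weak inhibition of growth. Among the measured compounds shown here, no pair of measured compounds differs in one place, so no measured step is available.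

Compound 3, `CSc1nc(NCCCCCO)c2ccccc2n1`, is not yet measured. It differs from compound 2 by 4-hydroxybutyl in place of phenyl on a saturated chain carbon bound to a nitrogen on an aromatic ring. For the measured compounds named here, with no measured step to lean on, the expectation rests on the weak position of compound 2 at 82300 nM. Compound 1, for its part, sits at a limit of the assay. Compound 3 is expected to stay weak, and the step of a 1.1-fold higher number from compound 2 to compound 3 (0.04 log units; within the scatter) is expected to be small, toward weaker or none beyond the scatter. Compound 3 is estimated at 90000 nM, within 30000 nM to 250000 nM.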

Compound 3, concentration for total growth inhibition: 71400 nM
Compound 3: middle estimate off by 1.3-fold (0.10 log units), on the high side, and the stated range covers the measured number.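

In this assay, 4-hydroxybutyl in place of phenyl gives a 1.2-fold lower number from compound 2 to compound 3 (0.06 log units; within the scatter), so at this position an open chain with no ring, carrying a hydrogen-bond donor and acceptor, leaves the number within the scatter of the phenyl compound. The second comparison, 2-hydroxyethyl in place of phenyl further along the chain, gives an at least 1.4-fold lower number from compound 1 to compound 3 (0.14 log units; that floor lies within the scatter); this is only a floor, and it does not establish a real difference. Compound 1 stays at a limit of the assay, not a number: the limit of > 100000 nM in this assay, at which 1 of the 3 values shown sits.

Going by these compounds, all three results remain weak, so it is open whether any group at this position can move the number beyond the scatter. An amine or a carboxylic acid in place of the hydroxy group, or a longer chain, would test this.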